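Replacing aminophenyl with dichlorophenyl: an untested analogue

The compounds below may be only part of what the source reports. "The series", "measured", "known", "first", "only" and "open" are said of these compounds alone.

Of the compounds shown here, two sharing a common core have been measured in a functional assay on TK-10 cells (Homo sapiens) for cytotoxicity, read by sulforhodamine B assay, with a stated time of 48 h, tested at 10 uM; on this read-out lower numbers stand for a stronger effect and higher numbers for a weaker effect at the one concentration tested. Compound 1 `COc1cc(-c2cc(/C=C/C(=O)c3ccc(N)cc3)[nH]n2)cc(OC)c1OC` gives 26%, the highest of the two numbers and therefore the weaker effect of the pair. Compound 2 `COc1ccc(-c2cc(/C=C/C(=O)c3ccc(OC)c(OC)c3)[nH]n2)cc1` gives -59%, a number far lower than that of compound 1 and well beyond the usual scatter, which marks a much stronger effect at the single concentration tested. The two structures differ in more than one place, so no single change can be credited with that gap.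

Compound 3 `COc1cc(-c2cc(/C=C/C(=O)c3ccc(Cl)c(Cl)c3)[nH]n2)cc(OC)c1OC` has not yet been measured in this assay. It is built from compound 1 by one change: 3,4-dichlorophenyl in place of 4-aminophenyl on a carbonyl carbon. Going by the values given here, no measured pair shows this change on its own, so its consequence can only be estimated. The expectation is that the step of a number 21 percentage points lower from compound 1 to compound 3 (beyond the scatter) points downward, toward a stronger effect, though with considerable uncertainty. In this assay compound 3 is expected to give about 5%, with a plausible range from -50% to 50%.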

Compound 3, a percentage reported as activity, at one concentration (the size of the read-out at that concentration, not a potency): 46%
The estimate for compound 3 lay 41 percentage points below the measured number; measured number inside the range.
By their numbers in this assay, from the lowest: compound 2; then compound 1; then compound 3.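

In this assay, putting 3,4-dichlorophenyl in place of 4-aminophenyl on a carbonyl carbon moves the read-out a number 20 percentage points higher from compound 1 to compound 3 (beyond the scatter), so on this core the change gives a modestly weaker effect, not a stronger one. This is the only pair shown that differs in one place, and it gives the first direct sign that the group on this carbonyl carbon can alter the result: here, the group with two chlorine atoms and no hydrogen-bond donor brought no gain over 4-aminophenyl. No measurement available here accounts for the shift.

A single pair cannot separate the effect of removing the amine from the effect of adding the two chlorine atoms. On these data alone, it also remains open where a 4-fluorophenyl group or a phenyl ring carrying a carboxylic acid on this carbonyl carbon would fall relative to compound 1 and compound 3, and whether the same swap would act in the same direction on the core of compound 2.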